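Regioisomeric triazole ester in a dihydropyridine series

The source may report more compounds than this note shows. Statements on the series, on what has been measured and on what is new or still open speak of the compounds shown alone.

Compound 2 `CCOC(=O)c1cnnn1CCOCC1=NC(C)=C(C(=O)OC)C(c2ccccc2Cl)/C1=C(\O)OCC` is the weakest of the three measured compounds in a functional assay (aorta) with Rattus norvegicus as the target (a higher number here means a weaker inhibitor, a lower number a stronger inhibitor), giving 100 nM. Compound 1 `CCO/C(O)=C1\C(COCCn2cc(N)n(C)c2=O)=NC(C)=C(C(=O)OC)C1c1ccccc1Cl` gives 25.1 nM in this assay, and compound 3 `CCO/C(O)=C1\C(COCCN2CC(=O)N(C)C2=O)=NC(C)=C(C(=O)OC)C1c1cccc(Cl)c1Cl` gives 5.01 nM. Going by the values given here, the one measured step, a 4.0-fold higher number from compound 1 to compound 2 (0.60 log units; beyond the scatter), concerns an exchange of the whole ring group on the side chain and so does not directly address the change now in question. Compound 4 `CCOC(=O)c1cn(CCOCC2=NC(C)=C(C(=O)OC)C(c3ccccc3Cl)/C2=C(\O)OCC)nn1` differs from compound 2 only in the position of the ester on the triazole: 4-(ethoxycarbonyl)-1H-1,2,3-triazol-1-yl in place of 5-(ethoxycarbonyl)-1H-1,2,3-triazol-1-yl on a saturated chain carbon, two bonds along the chain from an oxygen on a saturated carbon. No measured pair here separates the two regioisomers of this ring, so the move has no precedent among these compounds; the step from compound 1 to compound 2 shows only that swapping the entire ring group shifts the number modestly. He therefore expects compound 4 to stay close to compound 2, with a step of a 1.3-fold lower number from compound 2 to compound 4 (0.10 log units; within the scatter) that is not beyond the scatter. His estimate for compound 4 in this assay is 80 nM, within a range from 30 nM to 250 nM.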

Compound 4, half-maximal inhibitory concentration: 50.1 nM
Compound 4: middle estimate off by 1.6-fold (0.20 log units), on the high side, and the stated range covers the measured number.
By their numbers in this assay, from the lowest: compound 3; then compounds 1, 4 and 2 (each within the scatter of the next, the first and the last beyond it).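

In this assay, moving the ester from 5-(ethoxycarbonyl)-1H-1,2,3-triazol-1-yl to 4-(ethoxycarbonyl)-1H-1,2,3-triazol-1-yl gives a 2.0-fold lower number from compound 2 to compound 4 (0.30 log units; within the scatter), so the two regioisomers cannot be told apart at this saturated chain carbon. The exchange of the whole ring group, which gave a 4.0-fold higher number from compound 1 to compound 2 (0.60 log units; beyond the scatter) with the 5-ester, gives a 2.0-fold higher number from compound 1 to compound 4 (0.30 log units; within the scatter) with the 4-ester, so only the former is beyond the scatter, and the reading of that exchange depends on which regioisomer is taken. No supporting measurement bears on this result.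

The compounds shown leave open how a carboxylic acid in place of the ethoxycarbonyl group would read at either ring position. Going by these compounds, a longer chain carrying the 4-(ethoxycarbonyl)-1H-1,2,3-triazol-1-yl group also remains open.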